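Cyclopropyl replaces trifluoromethyl in a Vero cell inhibition series

The source may hold more compounds than are shown below. What is called first, only, known or untested is meant among the compounds shown, and "the series" means these compounds.

Compound 2 is `Cc1cc(C)c(-c2csc(NC(=O)/C=C/c3ccc(C(F)(F)F)cc3)n2)c(C)c1` and is the starting point of this account; in an ADME assay on Vero cells (Chlorocebus sabaeus) for inhibition, read by MTT assay, with a stated time of 96 h (a lower number here means a stronger inhibitor, a higher number a weaker inhibitor), compound 2 gives > 90000 nM, which is a limit of the assay and not a number. Its neighbour compound 1 is `Cc1cc(C)c(-c2csc(NC(=O)/C=C/c3ccc(C(C)(C)C)cc3)n2)c(C)c1`, and in this assay compound 1 gives > 90000 nM, again a limit. Going by the values given here, the one measured step, a step that the two limits leave unreadable from compound 1 to compound 2, therefore cannot be read, and all that can be said is the limit of > 90000 nM in this assay, at which 2 of the 2 values shown sit.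

The step under consideration leads to compound 3, `Cc1cc(C)c(-c2csc(NC(=O)/C=C/c3ccc(C4CC4)cc3)n2)c(C)c1`. It differs from compound 2 as follows: cyclopropyl in place of trifluoromethyl on an aromatic carbon.

Among the compounds with values here, only the step from compound 1 to compound 2 lies close to this change, and its size is hidden by the limits, so it gives no direction. With both measured values sitting at the limit, the expectation for compound 3 is that it also reaches no readable number in this assay; the expected step that the limit leaves unreadable from compound 2 to compound 3 is none beyond the scatter. Compound 3 is therefore estimated at 100000 nM in this assay, with a range from 40000 nM to 300000 nM.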

Compound 3, half-maximal inhibitory concentration: > 90000 nM
Compound 3 gave a limit, no number; the forecaster's own chance of this, stated with the estimate: 80%; the middle value does not contradict the limit.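

In this assay compound 3 gives > 90000 nM as a limit of the assay and not a number. Going by these compounds alone, no step among compound 1, compound 2 and compound 3 can be read, and the series ends at one value: the limit of > 90000 nM in this assay, at which 3 of the 3 values shown sit. The compounds shown leave open whether any group in this place on the shared core gives a readable number in this assay.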